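Swapping Fluoro for Hydroxy in a Growth Inhibitor Series

The source may hold more compounds than are shown below. What is called first, only, known or untested is meant among the compounds shown, and "the series" means these compounds.

Three related compounds have been tested so far in a functional assay on CCRF-CEM cells (Homo sapiens) for inhibition; on this read-out lower numbers stand for stronger inhibition of growth and higher numbers for weaker inhibition of growth. Compound 1 (`NS(=O)(=O)c1ccc(/C=C/c2ccc(O)c(O)c2)cc1`) gives 4790 nM, and compound 2 (`COc1cccc(/C=C/c2ccc(S(N)(=O)=O)cc2)c1`) gives 13600 nM. Compound 3 (`NS(=O)(=O)c1ccc(/C=C/c2ccc(F)cc2)cc1`) gives 62000 nM, the highest number of the three and so the weakest inhibition of growth, with a gap to each of the others that lies beyond the usual scatter of repeated measurements.

Compound 4 (`NS(=O)(=O)c1ccc(/C=C/c2ccc(O)cc2)cc1`) has not been measured yet. It differs from compound 3 in a single place, with hydroxy in place of fluoro on an aromatic carbon, para to a large group (hydroxy in place of fluoro on an aromatic carbon). For the measured compounds named here, no two measured compounds differ in only one place, so no direct measurement shows what this swap does. Going by the values given here, the one guide is indirect: compound 1, the only measured compound that carries hydroxy, gives 4790 nM. That compound also differs from compound 3 in other ways, so the guide is a loose one. In this assay the expected change is a 3.9-fold lower number from compound 3 to compound 4 (0.59 log units; beyond the scatter), a moderate move toward stronger inhibition of growth. For compound 4 the estimated value is 16000 nM, with an expected range of 5500 nM to 45000 nM.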

Compound 4, concentration for 50% growth inhibition: 4500 nM
Compound 4: the middle estimate sits 3.6-fold (0.55 log units) above what was measured; the measured number lies below the stated range.
By their numbers in this assay, from the lowest: compounds 4 and 1 (each within the scatter of the next); then compound 2; then compound 3.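

In this assay, for the compounds shown here, this is the first direct reading of what the group at this place does: with hydroxy in place of fluoro on an aromatic carbon, para to a large group, the step is a 14-fold lower number from compound 3 to compound 4 (1.14 log units; beyond the scatter) and counts as large. Growth inhibition in this series therefore depends strongly on which of these two single-atom groups sits at this position, a dependence that the earlier compounds, none of which differed in only one place, could not show on their own. The second hydroxy of compound 1 adds nothing that can be detected, since hydrogen in its place gives a 1.1-fold lower number from compound 1 to compound 4 (0.03 log units; within the scatter), so one hydroxy at this position is enough to reach this level, and no measurement available here explains why the swap from fluoro to hydroxy has such a large effect.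

On these data alone, with only fluoro and hydroxy compared at this position, it remains open whether an amine or a carboxylic acid there would behave like hydroxy or fall back toward the level of fluoro. Plain hydrogen at this same place is also untested in the compounds shown, so it is unclear how much of the step comes from adding hydroxy and how much from removing fluoro.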